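The compounds below may be only part of what the source reports. "The series", "measured", "known", "first", "only" and "open" are said of these compounds alone.

Measured so far in an ADME assay on HEK293 cells (Homo sapiens) for inhibition, read by MTT assay, with a stated time of 48 h; on this read-out higher numbers stand for weaker inhibition and lower numbers for stronger inhibition:
compound 1 `CC1CCN(c2ccc(Nc3ncc4c(n3)N(C3CCCC3)CC(=O)N4C)cc2)CC1` — "not determined" (no result reported)
compound 2 `CCN1C(=O)CN(C2CCCC2)c2nc(Nc3ccc(N4CCCCC4)cc3)ncc21` — > 30000 nM

Compound 1 carries no number in this assay, only "not determined" (no result reported). For compound 2 this assay gives only a limit, > 30000 nM, not a measured number. Among the compounds with values here, compound 2 thus sits at the limit of > 30000 nM in this assay, at which 1 of the 2 values shown sits, and with compound 1 lacking a value there is no step between measured compounds to weigh.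

Compound 3 `CCN1C(=O)CN(C2CCCC2)c2nc(Nc3ccc(N4CCC(C)CC4)cc3)ncc21` differs from compound 2 by methyl in place of hydrogen on a saturated ring carbon. The step from compound 2 to compound 3 is expected to be a step that the limit leaves unreadable from compound 2 to compound 3, none beyond the usual scatter. Compound 3 is therefore estimated at 40000 nM, within 15000 nM to 100000 nM, most likely again reported only as a limit.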

Compound 3, half-maximal inhibitory concentration: > 30000 nM
Compound 3: no number, only a limit (the forecaster's own chance of this, stated with the estimate: 75%); the middle value is on the limit's open side.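

No step can be read from compound 2 to compound 3 in this assay, as both compounds give only a limit. Still open, as far as these compounds go, is whether piperidin-1-yl to 4-methylpiperidin-1-yl changes inhibition at all, as neither compound has a measured number.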